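Cinnamyl piperidine carboxanilides: aryl substituent and A549 growth inhibition

The source may hold more compounds than are shown below. What is called first, only, known or untested is meant among the compounds shown, and "the series" means these compounds.

Measured so far:
Compound 1 `CCCCCc1ccc(NC(=O)C2CCN(C/C=C/c3ccccc3)CC2)cc1` — 3880 nM
Compound 2 `COc1ccc(NC(=O)C2CCN(C/C=C/c3ccccc3)CC2)cc1` — 83800 nM

Both compounds share the piperidine carboxamide bearing the cinnamyl group and differ only on the anilide ring. In a functional assay on A549 cells (Homo sapiens) for inhibition, read by MTT assay, with a stated time of 72 h (on this read-out higher numbers stand for weaker inhibition and lower numbers for stronger inhibition), compound 1 gives 3880 nM, while compound 2 gives 83800 nM; the change a 22-fold higher number from compound 1 to compound 2 (1.33 log units; beyond the scatter) is a large one. Compound 2 therefore stands at the weakest end of the two numbers available, well beyond the scatter from compound 1.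

Compound 3 `O=C(Nc1cccc(Br)c1)C1CCN(C/C=C/c2ccccc2)CC1` is not yet measured. Relative to compound 2 the change is 3-bromophenyl in place of 4-methoxyphenyl on an amide-type nitrogen. Among the measured compounds shown here, no measured step covers a bromine on the anilide ring, nor a shift of the substituent to the 3-position; the only step recorded, a 22-fold higher number from compound 1 to compound 2 (1.33 log units; beyond the scatter), shows that the anilide substituent moves the number by a large amount. Given that sensitivity, the step of a 5.6-fold lower number from compound 2 to compound 3 (0.75 log units; beyond the scatter) is expected to be a move back towards stronger inhibition, but of uncertain size. Compound 3 is thus estimated at 15000 nM, with a range from 3000 nM to 70000 nM, pending measurement.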

Compound 3, half-maximal inhibitory concentration: 16500 nM
The estimate for compound 3 lay 1.1-fold (0.04 log units) below the measured number, and the stated range covers the measured number.
By their numbers in this assay, from the lowest: compound 1; then compound 3; then compound 2.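

In this assay, the aryl group on the amide-type nitrogen again moves the number, with a 5.1-fold lower number from compound 2 to compound 3 (0.71 log units; beyond the scatter), so the lower numbers in this short set are not confined to the pentyl-bearing compound 1. The step is smaller than the one between the first two compounds, and compound 3 at 16500 nM still stands on the higher side of compound 1 at 3880 nM, so 3-bromophenyl recovers only part of the gap on the printed values. The exchange removes the single hydrogen-bond acceptor counted in 4-methoxyphenyl and brings in bromine, but no measurement here ties the step to either feature or to any property of these groups.

The compounds shown leave open how much of the step belongs to bromine itself and how much to where it sits, since 3-bromophenyl and 4-methoxyphenyl differ in both the substituent and its place on the ring. Also open, going by these compounds, is how an amine, a carboxylic acid or a chain longer than pentyl on this aryl group would read in this assay.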